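Aryl swap on compound 3: toward compound 4

A few compounds are considered here, and "the series" means these few. Any claim that something is new, unique, unknown or untested is made for them only; others in the source may bear on it.

Compound 1 `Cc1ccc(-c2cc(COC3(C(F)(F)F)Oc4ccccc4C=C3C(=O)O)on2)cc1` is the only one of the three measured compounds with a number rather than a limit; in a functional assay on HeLa cells (Homo sapiens) for inhibition, read by MTT assay, with a stated time of 24 h (on this read-out lower numbers stand for stronger inhibition and higher numbers for weaker inhibition), compound 1 gives 33400 nM. Compound 2 `O=C(O)C1=Cc2ccccc2OC1(OCc1cc(-c2ccc3ccccc3c2)no1)C(F)(F)F` carries naphthalen-2-yl, and in this assay compound 2 gives only the limit > 150000 nM. Compound 3 `O=C(O)C1=Cc2ccccc2OC1(OCc1cc(-c2ccc(F)cc2F)no1)C(F)(F)F` carries 2,4-difluorophenyl, and in this assay compound 3 gives only the limit > 150000 nM. Compound 3 thus stands at the limit of > 150000 nM in this assay, at which 2 of the 3 values shown sit, together with compound 2. The steps of an at least 4.4-fold higher number from compound 1 to compound 2 (0.65 log units; beyond the scatter) and an at least 4.4-fold higher number from compound 1 to compound 3 (0.65 log units; beyond the scatter) were both at least modest, while the step that the two limits leave unreadable from compound 2 to compound 3 cannot be read from two limits.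

Compound 4 `COc1ccc(-c2cc(COC3(C(F)(F)F)Oc4ccccc4C=C3C(=O)O)on2)cc1` is the change (4-methoxyphenyl in place of 2,4-difluorophenyl on an aromatic carbon). Among the compounds with values here, no measured step exchanges one para-substituted phenyl for another; the nearest information is that compound 1, with 4-methylphenyl, is the one compound that reaches a number, 33400 nM. Compound 4 is expected to move back toward that number. The expected step of an at least 3.0-fold lower number from compound 3 to compound 4 (0.47 log units; beyond the scatter) therefore runs toward lower numbers, though a further limit remains possible. Compound 4 is estimated at 50000 nM, in the range 20000 nM to 150000 nM.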

Compound 4, half-maximal inhibitory concentration: > 150000 nM
Compound 4 ended at the assay's limit (the forecaster's own chance of this, stated with the estimate: 35%); at least 3.0-fold (0.47 log units) between middle value and limit.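

Until now the aryl changes replaced the whole group; here only the methyl of compound 1 is exchanged for methoxy, and that single exchange gives an at least 4.4-fold higher number from compound 1 to compound 4 (0.65 log units; beyond the scatter) in this assay. The 4-substituted phenyl is therefore not enough on its own to keep a number at this position on the five-membered ring. Compound 4 gives only a limit of the assay, as compounds 2 and 3 do, so the steps among these three cannot be read, and the one number in the set rests on compound 1 alone: the limit of > 150000 nM in this assay, at which 3 of the 4 values shown sit.

From the compounds shown here alone, how far the three limited compounds lie past the limit stays open. Also open, going by these compounds, is whether an ethyl, a chlorine or an amine in place of the methyl of compound 1 would keep a number or end at the limit too.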